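The source may report more compounds than this note shows. Statements on the series, on what has been measured and on what is new or still open speak of the compounds shown alone.

Working notes on the series. Compound 1 `CN1C[C@@H](COc2ccc(C(=O)N(C)c3cccc(CC(=O)O)c3)cc2)Oc2ccccc21` carries a methyl on the amide nitrogen; in a functional assay on CHO cells for antagonist activity at prostaglandin D2 receptor (Mus musculus), read by cAMP accumulation (on this read-out higher numbers stand for weaker inhibition and lower numbers for stronger inhibition), compound 1 gives "not determined" (no result reported), so it offers no number to compare. Among the measured compounds shown here, compound 2 `CN1C[C@@H](COc2ccc(C(=O)Nc3cccc(CC(=O)O)c3)c(Cl)c2)Oc2ccccc21` is the only member with a reading: in this assay compound 2 gives 20 nM, which is therefore the sole reference point of the set, with no second number to rank it against.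

Compound 3 `CN1C[C@@H](COc2ccc(C(=O)Nc3ccc(F)c(CC(=O)O)c3)c(Cl)c2)Oc2ccccc21` differs from compound 2 by one change, (fluoro in place of hydrogen on an aromatic carbon), that is, fluoro in place of hydrogen on an aromatic carbon. For the measured compounds named here, no pair of measured compounds with this change is available, so the expected step from compound 2 to compound 3 rests on the reading of compound 2 alone and on the small size of the change. A step of about a 1.3-fold lower number from compound 2 to compound 3 (0.12 log units; within the scatter) is expected, within the scatter or a shade toward stronger inhibition. Compound 3 is estimated at 15 nM, with a range from 5 nM to 50 nM.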

Compound 3, half-maximal inhibitory concentration: 50 nM
Estimate against measurement, compound 3: 3.3-fold (0.52 log units) below; low and high end bracket the measured number.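

Fluoro in place of hydrogen on this aromatic carbon, ortho to a carboxymethyl group and para to a large group, is not a neutral change: in this assay it gives a 2.5-fold higher number from compound 2 to compound 3 (0.40 log units; beyond the scatter), a modest step toward weaker inhibition. Among the compounds shown here, this is the first step that can be read, and it shows that the position responds to the addition of a single fluorine atom, with compound 2 the stronger of the pair. Nothing available accounts for the size or direction of this step.

Going by these compounds, whether the weakening is specific to fluoro or would also follow chloro, methyl or methoxy on the same carbon remains open. Also open, on these data alone, is whether fluoro on another carbon of this ring would give a similar step.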